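Chloro to methoxy on the core of compound 1: compound 3

This account rests on a few compounds, and the source may have more. Where it says the series, first, only, none or still open, it means among the compounds named here.

Measured so far:
compound 1, `COc1c(/C=C2/C(=O)Nc3ccc(Cl)cc32)c2ccccc2n1-c1ccccc1`: 5620 nM
compound 2, `O=C1/C(=C/c2c(Cl)[nH]c3ccccc23)c2ccccc2N1Cc1ccccc1`: 5130 nM

Both compounds were run in a functional assay on cells (Melanoma cell, Homo sapiens) for cytotoxicity, with a stated time of 48 h; on this read-out higher numbers stand for weaker inhibition of growth and lower numbers for stronger inhibition of growth. Compound 1 gives 5620 nM in this assay, and compound 2 gives 5130 nM. The two values lie within the scatter of each other, so compound 1 stands level with compound 2 on the numbers shown; no pattern can be drawn from two compounds that do not separate.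

Compound 3, `COc1ccc2c(c1)/C(=C\c1c(OC)n(-c3ccccc3)c3ccccc13)C(=O)N2`, is not yet measured. It differs from compound 1 in one place: methoxy in place of chloro on an aromatic carbon. For the measured compounds named here, no measured pair shows this exchange, so there is no step to lean on. The shared core and the rest of the substitution are unchanged, and the step is expected to be small, a 1.2-fold higher number from compound 1 to compound 3 (0.10 log units; within the scatter), with no direction beyond the scatter.

For compound 3 the estimate in this assay is 7000 nM, with a range from 2500 nM to 20000 nM.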

Compound 3, concentration for 50% growth inhibition: 2400 nM
For compound 3 the middle estimate is 2.9-fold (0.46 log units) above the measured one, outside the stated range (below it).
By their numbers in this assay, from the lowest: compound 3; then compounds 2 and 1 (each within the scatter of the next).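

In this assay, for the compounds shown here, methoxy in place of chloro on this aromatic carbon gives a 2.3-fold lower number from compound 1 to compound 3 (0.37 log units; beyond the scatter) and is the first difference that stands clear of the scatter. The position is therefore not silent: with methoxy here, inhibition of growth becomes stronger rather than weaker, although this rests on a single pair and sets no trend. Nothing on hand accounts for the step.

As far as these compounds go, whether the gain is specific to methoxy remains open, as does whether it would hold for other groups on this carbon, such as an amine, a hydroxyl or a longer ethoxy chain. Also open, from the compounds shown here alone, is whether the same exchange would act alike on the differently substituted compound 2.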